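Butyl Ketone in Place of a Diethylaminoethyl Amide

A few compounds are considered here, and "the series" means these few. Any claim that something is new, unique, unknown or untested is made for them only; others in the source may bear on it.

Measured compounds:
compound 1 `CCn1c(C(=O)NCCC(=O)OC)ccc1C(CC)(CC)c1ccc(C#CC(O)(CC)CC)c(C)c1` — in an assay on cells for agonist activity at vitamin D3 receptor (Homo sapiens), read by microscopy (a lower number here means that less compound is needed, a higher number that more compound is needed for the effect), compound 1 gives > 50 nM, which is a limit of the assay and not a number.
compound 2 `C#CCCOC(=O)c1ccc(C(CC)(CC)c2ccc(C#CC(O)(CC)CC)c(C)c2)n1CC` — compound 2 gives > 50 nM, again a limit and not a number.
compound 3 `CCN(CC)CCNC(=O)c1cc(C(CC)(CC)c2ccc(C#CC(O)(CC)CC)c(C)c2)cn1CC` — compound 3 gives 6.98 nM.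

Within the data shown here, compound 3 carries the only number among the three values; the other two values are limits. Among the measured compounds shown here, the one step between measured compounds, a step that the two limits leave unreadable from compound 1 to compound 2, cannot be read because both of its ends are limits, so no measured step gives a size to work from. For the measured compounds named here, the pair compound 1 and compound 3, and the pair compound 2 and compound 3, have no computed step; their values show only that compound 3 has a number where the other two reach the limit.

Compound 4 `CCCCC(=O)c1cc(C(CC)(CC)c2ccc(C#CC(O)(CC)CC)c(C)c2)cn1CC` differs from compound 3 by butyl in place of (2-(diethylamino)ethyl)amino on a carbonyl carbon. Going by the values given here, no measured step maps onto this change. The expectation for compound 4 in this assay is therefore loose, leaning weaker, because two of the three values sit at the limit of > 50 nM in this assay, at which 2 of the 3 values shown sit, and only the compound bearing the (2-(diethylamino)ethyl)amino group has a number. Compound 4 is estimated at 60 nM, between 8 nM and 400 nM, which is an expected step of an 8.6-fold higher number from compound 3 to compound 4 (0.93 log units; beyond the scatter).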

Compound 4, half-maximal effective concentration: > 50 nM
Compound 4: a limit, no number; the forecaster's own chance of this, stated with the estimate: 50%; the middle value is on the limit's open side.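

Compound 4 gives > 50 nM in this assay, which is a limit of the assay and not a number. Among these compounds, putting butyl in place of (2-(diethylamino)ethyl)amino on a carbonyl carbon gives an at least 7.1-fold higher number from compound 3 to compound 4 (0.85 log units; beyond the scatter), the first step in this set that can be read, and it shows that the change costs more than the usual scatter, though only its minimum size is known. The earlier compounds could not show this, since their one step had a limit at both ends; the single number in the set still belongs to the compound carrying the (2-(diethylamino)ethyl)amino group, and the limit now holds most of the set: the limit of > 50 nM in this assay, at which 3 of the 4 values shown sit.

As far as these compounds go, whether butylamino on the same carbonyl carbon, which would keep the amide hydrogen but lose the diethylamino end, or a smaller dimethylamino end or a carboxylic acid there would give a number remains open. So the compounds shown do not separate the part played by the amide from that of the terminal amine, and the full size of the step stays unknown.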